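Flipping the Phosphorus Centre of a Thiophosphate Nucleotide

This account rests on a few compounds, and the source may have more. Where it says the series, first, only, none or still open, it means among the compounds named here.

Measured compounds:
- Compound 1, `B[PH](O)(OC[C@H]1OC(n2cnc3c(N)ncnc32)[C@H](O)[C@@H]1O)OP(=O)(O)OP(=O)(O)O`: 200 nM; > 1000 nM (2 entries)
- Compound 2, `CSc1nc(N)c2ncn(C3O[C@H](CO[P@](O)(=S)OP(=O)(O)OP(=O)(O)O)[C@@H](O)[C@H]3O)c2n1`: 1 nM

In a functional assay on HEK293 cells with P2Y purinoceptor 1 (Rattus norvegicus) as the target, read by calcium flux (on this read-out higher numbers stand for an effect only at larger amounts of compound and lower numbers for an effect already at smaller amounts), compound 1 gives 200 nM; > 1000 nM (2 entries). For compound 1, the entries marked with a "greater than" sign are limits of the assay rather than numbers, so its several entries the several entries of compound 1 in this assay, 200 nM; > 1000 nM (2 entries) do not settle on a single value. Compound 2, in contrast, gives 1 nM in this assay, the only number shown for it, and on that number it is the most potent of the two.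

Compound 3, `CSc1nc(N)c2ncn(C3O[C@H](CO[P@@](O)(=S)OP(=O)(O)OP(=O)(O)O)[C@@H](O)[C@H]3O)c2n1`, is not yet measured. It differs from compound 2 only in stereochemistry: the two compounds have the same atoms and bonds; at least one stereo element is drawn with a configuration in one of them and without one in the other: 1 of 6 stereo elements differ; a stereocentre at a phosphorus is drawn S in compound 2 and R in compound 3. Among the compounds with values here, no measured pair here shows what such an inversion does. My expectation is a modest loss of potency, with the step from compound 2 to compound 3 expected to be a 10-fold higher number from compound 2 to compound 3 (1.00 log units; beyond the scatter) in this assay. Compound 3 is therefore estimated at 10 nM, within a range from 2 nM to 100 nM.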

Compound 3, half-maximal effective concentration: 20 nM
Beside the measured number, compound 3's estimate is 2.0-fold (0.30 log units) below it; low and high end bracket the measured number.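

In this assay, inverting the stereocentre at the phosphorus alone gives a 20-fold higher number from compound 2 to compound 3 (1.30 log units; beyond the scatter), so the spatial arrangement at this one phosphorus matters even with every atom and bond unchanged. Compound 1, which differs from compound 2 in more than one place, offered no such comparison. This reading rests on a feature of the drawings themselves: the fact that one of compounds 2 and 3 is drawn with a defined configuration and the other without, at the place where they differ

The compounds shown leave open how the two arrangements at the phosphorus compare when the sulfur there gives way to another group, such as a selenium atom or a methyl group. Within the data shown here, they also leave open whether the same inversion brings a step of similar size on a different core, with compound 2 and compound 3 the only pair that carries it.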